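Phenyl amide series: working notes ahead of compound 4

The source may hold more compounds than are shown below. What is called first, only, known or untested is meant among the compounds shown, and "the series" means these compounds.

- compound 1 `O=C(CCc1cccc2c1B(O)OC2)Nc1ccccc1` gives 30000 nM
- compound 2 `CC(C)(C)c1ccc(NC(=O)CCc2cccc3c2B(O)OC3)cc1` gives 55000 nM
- compound 3 `COc1ccc(NC(=O)CCc2cccc3c2B(O)OC3)cc1` gives > 100000 nM (a limit)

The assay is an ADME assay on WI-38 cells (Homo sapiens) for cytotoxicity, read by MTT assay, with a stated time of 72 h; a lower number here means a stronger inhibitor, a higher number a weaker inhibitor. Compound 1 and compound 2 lie within the scatter of each other, and compound 3 sits at a limit. Compound 4 `O=C(CCc1cccc2c1B(O)OC2)Nc1cccc(Br)c1` has bromo in place of hydrogen on an aromatic carbon of compound 1 (bromo in place of hydrogen on an aromatic carbon). Among the compounds with values here, no measured compound carries bromo. The nearest guides are two other substitutions, a 1.8-fold higher number from compound 1 to compound 2 (0.26 log units; within the scatter) and an at least 3.3-fold higher number from compound 1 to compound 3 (0.52 log units; beyond the scatter). Only the second is beyond the scatter. A small move towards a higher number is therefore expected, with the expected step of a 1.2-fold higher number from compound 1 to compound 4 (0.07 log units; within the scatter) staying within the scatter. Compound 4 is expected at 35000 nM, with an estimated range of 15000 nM to 90000 nM.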

Compound 4, half-maximal inhibitory concentration: 20000 nM
Estimate against measurement, compound 4: 1.8-fold (0.24 log units) above; the measured number falls inside the stated range.
By their numbers in this assay, from the lowest: compounds 4, 1 and 2 (each within the scatter of the next, the first and the last beyond it). At a limit, above all of these: compound 3.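

In this assay, the phenyl to 3-bromophenyl change gives a 1.5-fold lower number from compound 1 to compound 4 (0.18 log units; within the scatter). On this evidence, a single bromine atom on the aromatic carbon meta to a large group does not move the reading beyond the scatter, and compound 4 gives a number rather than a limit. Compound 3 alone stays at a limit: the limit of > 100000 nM in this assay, at which 1 of the 4 values shown sits.

As far as these compounds go, what an amine or a carboxylic acid at this position would give remains open. So does whether bromo on another carbon of the ring would read the same.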